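Replacing the anilide aryl group with pyridin-2-yl

The source may report more compounds than this note shows. Statements on the series, on what has been measured and on what is new or still open speak of the compounds shown alone.

Compound 3 `COc1cccc(NC(=O)COc2ccc3cc(/C=C4/SC(=O)NC4=O)ccc3c2)c1` belongs to a set of three analogues that share one core and differ only in the aryl group carried on the amide-type nitrogen. In an assay on isolated protein for inhibition of histone deacetylase 8 (Homo sapiens), with a stated time of 1 h (a lower number here means a stronger inhibitor, a higher number a weaker inhibitor), compound 3 gives 7600 nM, the lowest of the two numbers recorded. Compound 1 `Cc1ccc(NC(=O)COc2ccc3cc(/C=C4/SC(=O)NC4=O)ccc3c2)cc1`, which carries 4-methylphenyl, gives 9000 nM in this assay, so that a 1.2-fold lower number from compound 1 to compound 3 (0.07 log units; within the scatter). Compound 2 `O=C(COc1ccc2cc(/C=C3/SC(=O)NC3=O)ccc2c1)Nc1ccc(Br)cc1F`, with 4-bromo-2-fluorophenyl, returns only a limit of this assay, > 50000 nM. Because of the limit of > 50000 nM in this assay, at which 1 of the 3 values shown sits, the steps involving compound 2 can only be bounded: an at least 5.5-fold higher number from compound 1 to compound 2 (0.74 log units; beyond the scatter), and an at least 6.5-fold lower number from compound 2 to compound 3 (0.81 log units; beyond the scatter).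

Compound 4 `O=C(COc1ccc2cc(/C=C3/SC(=O)NC3=O)ccc2c1)Nc1ccccn1` has not yet been measured. It differs from compound 3 in one place: pyridin-2-yl in place of 3-methoxyphenyl on an amide-type nitrogen. The exchange of one aryl group for another at this position has been followed twice. The swap of 4-methylphenyl for 3-methoxyphenyl left the number within the scatter, whereas the halogenated ring pushed it past the limit. Pyridin-2-yl resembles neither exactly, so the expectation for compound 4 is a small step, most likely toward a higher number: a 1.6-fold higher number from compound 3 to compound 4 (0.20 log units; within the scatter) is expected. Compound 4 is therefore estimated at 12000 nM in this assay, within a range from 4000 nM to 45000 nM.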

Compound 4, half-maximal inhibitory concentration: > 50000 nM
Compound 4: only a limit was reported; the forecaster's own chance of this, stated with the estimate: 20%; at least 4.1-fold (0.61 log units) between middle value and limit.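

In this assay, the exchange of 3-methoxyphenyl for pyridin-2-yl gave an at least 6.5-fold higher number from compound 3 to compound 4 (0.81 log units; beyond the scatter), and the exchange of 4-methylphenyl for the same ring gave an at least 5.5-fold higher number from compound 1 to compound 4 (0.74 log units; beyond the scatter). Before this result, only the halogenated ring of compound 2 had reached a limit, so the loss could have been tied to that single group; compound 4 carries no halogen and reaches a limit too, which shows that this position tolerates some aryl groups but not others, with compounds 1 and 3 on the readable side and compounds 2 and 4 at the limit. The step between compound 2 and compound 4 cannot be read, and neither can be ranked against the other, because both values are limits rather than numbers: the limit of > 50000 nM in this assay, at which 2 of the 4 values shown sit.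

Going by these compounds, what remains open is whether the ring nitrogen of pyridin-2-yl goes with the loss, which a plain phenyl group or a pyridin-3-yl group on the same amide-type nitrogen would help to settle. Also open, on these data alone, is whether a 3-aminophenyl group or a 3-carboxyphenyl group would keep a readable number in this assay, and how far compound 2 and compound 4 lie beyond their limits.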